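Notes on a chloro-for-hydrogen step in the series

The source may hold more compounds than are shown below. What is called first, only, known or untested is meant among the compounds shown, and "the series" means these compounds.

compound 1 `Cc1c(OCCCCOc2ccc(C(=O)O)cc2)ccc(C(=O)CC2CCCC2)c1O` — 82.6%
compound 2 `Cc1cc(C(=O)O)ccc1OCCCCOc1ccc(C(=O)CC(C)C)c(O)c1C` — 83.9%
compound 3 `Cc1c(OCCCCOc2ccccc2C(=O)O)ccc(C(=O)CC2CCCC2)c1C` — 67.1%

Three compounds have been run in an assay on HEK293 cells for positive allosteric modulation of metabotropic glutamate receptor 2 (Rattus norvegicus), read by thallium flux, with a stated time of 2.5 min; a lower number here means a smaller maximal response, a higher number a larger maximal response. Compound 1 gives 82.6% and stands second highest of the three numbers; compound 2 differs from it only within the scatter, while compound 3 lies lower, beyond the scatter.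

Compound 4 `Cc1c(OCCCCOc2ccc(C(=O)O)cc2Cl)ccc(C(=O)CC2CCCC2)c1O` has not yet been measured. It differs from compound 1 by chloro in place of hydrogen on an aromatic carbon. No two measured compounds differ in one place only, so nothing shown bears directly on this change. The step of a number 2.6 percentage points lower from compound 1 to compound 4 (within the scatter) is expected to stay within the scatter, with no direction favored. Compound 4 is estimated at 80%, between 65% and 95%.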

Compound 4, largest response reached (reported as percent of maximum), in percent of the reference or control that the assay uses: 82.2%
For compound 4 the middle estimate is 2.2 percentage points below the measured one, and the stated range covers the measured number.
By their numbers in this assay, from the lowest: compound 3; then compounds 4, 1 and 2 (each within the scatter of the next).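

In this assay the series gains its first one-place comparison, and a number 0.4 percentage points lower from compound 1 to compound 4 (within the scatter) with chloro in place of hydrogen on an aromatic carbon, ortho to a large group and meta to a carboxy group. The change from 4-carboxyphenyl to 4-carboxy-2-chlorophenyl therefore leaves the maximal response unmoved beyond the scatter on the core of compound 1. No measurement at hand offers an explanation for this result.

Still open, going by these compounds, is whether a methoxy group, a bromine atom or a nitrile on that carbon would also stay within the scatter. On these data alone, whether chloro gives the same result on the core of compound 2 also remains open.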